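The source may report more compounds than this note shows. Statements on the series, on what has been measured and on what is new or still open speak of the compounds shown alone.

In an ADME assay on J774 cells (Mus musculus) for cytotoxicity (on this read-out lower numbers stand for an effect already at smaller amounts and higher numbers for an effect only at larger amounts of compound), compound 1 `CCCCCCCCCc1c(C)[nH]c2ccccc2c1=O` gives 2800 nM and compound 3 `CCCCCCC/C=C/c1c(C)[nH]c2ccccc2c1=O` gives 28000 nM as the higher of the two numbers, a gap beyond the scatter. Compound 2 `Cc1[nH]c2ccccc2c(=O)c1Cc1ccccc1` has a phenyl-bearing side chain and gives > 40100 nM as a limit only, which tilts the expectation for compound 4 upward. Compound 4 `Cc1[nH]c2ccccc2c(=O)c1/C=C/c1ccccc1` remains unmeasured and differs from compound 3 by phenyl in place of heptyl on a double-bonded chain carbon bound to a double-bonded chain carbon in one place: phenyl in place of heptyl on a double-bonded chain carbon bound to a double-bonded chain carbon. The expected step of a 1.4-fold higher number from compound 3 to compound 4 (0.15 log units; within the scatter) in this assay leans towards a higher number but stays within the scatter. For compound 4 the estimated value is 40000 nM with an expected range from 15000 nM to 80000 nM for now.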

Compound 4, half-maximal effective concentration: > 36300 nM
Compound 4 was reported as a limit; the forecaster's own chance of this, stated with the estimate: 55%; the middle value does not contradict the limit.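

In this assay, phenyl in place of heptyl on a double-bonded chain carbon bound to a double-bonded chain carbon gives an at least 1.2-fold higher number from compound 3 to compound 4 (0.11 log units; that floor lies within the scatter). Compound 4 gives > 36300 nM, which is a limit and not a number. The change can therefore be read only as a floor, so a ring at this place is not shown to lower the number, and the full size of the step stays unknown: the limit of > 36300 nM in this assay, at which 1 of the 4 values shown sits.

On these data alone, whether the step truly exceeds the scatter remains open. Also open, as far as these compounds go, is how a longer chain or an amine at this place would read in this assay.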